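Predicting a thioamide-like substituent on a chromene core

The source may hold more compounds than are shown below. What is called first, only, known or untested is meant among the compounds shown, and "the series" means these compounds.

Measured so far:
compound 1 `CC1(C)C=C(n2ccccc2=O)c2ccccc2O1` gives 5.43
compound 2 `CCC(=O)c1ccc2c(c1)C(n1ccccc1=O)=CC(C)(C)O2` gives 6.63
compound 3 `CC(=O)Oc1ccc2c(c1)C(n1ccccc1=O)=CC(C)(C)O2` gives 5.6

These three compounds share one core and differ only in the group attached to an aromatic carbon of that core. In a functional assay (aorta) with Rattus norvegicus as the target (on this read-out higher numbers stand for higher potency (the scale is a negative logarithm) and lower numbers for lower potency), compound 1 stands lowest of the three numbers. Its nearest neighbour is compound 3, where a number 0.17 log units higher from compound 1 to compound 3 (within the scatter), a step within the usual scatter. The furthest is compound 2, where a number 1.20 log units higher from compound 1 to compound 2 (beyond the scatter). Between the two substituted compounds, a number 1.03 log units lower from compound 2 to compound 3 (beyond the scatter).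

Compound 4 `CC1(C)C=C(n2ccccc2=O)c2cc(C(=N)S)ccc2O1` is not yet measured. Relative to compound 1 the change is a group of 3 heavy atoms (1 carbon, 1 nitrogen, 1 sulfur; no ring) in place of a hydrogen atom, on an aromatic carbon. The two measured steps that bear on it both replace a hydrogen on the same kind of aromatic carbon: the propanoyl step was large, the acetoxy step negligible. The new group is neither of these, so a moderate rise is expected, a number 0.57 log units higher from compound 1 to compound 4 (beyond the scatter). Compound 4 is thus estimated at 6, with a range from 5.3 to 6.7.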

Compound 4, logarithm of the reciprocal of the active concentration, log(1/C): 6.21
The estimate for compound 4 lay 0.21 log units below the measured number; low and high end bracket the measured number.
By their numbers in this assay, from the lowest: compounds 1 and 3 (each within the scatter of the next); then compound 4; then compound 2.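

At this aromatic carbon, a rise does not depend on the propanoyl group: a quite different group, built from one carbon, one nitrogen and one sulfur and carrying no ring, also lifts the number by a modest step (a number 0.78 log units higher from compound 1 to compound 4 (beyond the scatter)). The new group also separates clearly from both earlier substituents, standing above the acetoxy group (a number 0.61 log units higher from compound 3 to compound 4 (beyond the scatter)) and below the propanoyl group (a number 0.42 log units lower from compound 2 to compound 4 (beyond the scatter)), so the three groups at this one place fall into a clear order. No measurement here explains why they fall in this order.

Open, on these data alone, is how an amide, with oxygen in place of the sulfur, or a nitrile would stand at this place. Also open, as far as these compounds go, is whether a longer chain such as butanoyl would exceed the propanoyl group.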